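The source may hold more compounds than are shown below. What is called first, only, known or untested is meant among the compounds shown, and "the series" means these compounds.

Among the measured compounds shown here, in a functional assay on KBVIN cells (Homo sapiens) for antiproliferative activity, read by sulforhodamine B assay, with a stated time of 3 days (a lower number here means that less compound is needed, a higher number that more compound is needed for the effect), compound 2 `CCCOc1ccc(-c2cc(=O)c3c(o2)C(CC)(CC)C(=O)C(CC)=C3O)cc1` gives 29.2 uM, the higher of the two numbers so far, while compound 1 `CCCc1ccc(-c2cc(=O)c3c(o2)C(CC)(CC)C(=O)C(CC)=C3O)cc1` gives 12.2 uM. Compound 3 `CCC1=C(O)c2c(oc(-c3ccc(Br)cc3)cc2=O)C(CC)(CC)C1=O` carries bromo in place of propoxy on an aromatic carbon, para to a large group (bromo in place of propoxy on an aromatic carbon). For the measured compounds named here, the only measured step at this site is a 2.4-fold higher number from compound 1 to compound 2 (0.38 log units; beyond the scatter), a modest change beyond the scatter, with propoxy in place of propyl. Removing the propoxy is therefore expected to lower the number modestly, an expected shift of a 1.9-fold lower number from compound 2 to compound 3 (0.29 log units; within the scatter). In this assay, compound 3 is estimated at 15 uM, with a range of 6 uM to 35 uM.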

Compound 3, concentration for half-maximal effect: 15.7 uM
Estimate against measurement, compound 3: 1.0-fold (0.02 log units) below, and the stated range covers the measured number.
By their numbers in this assay, from the lowest: compounds 1, 3 and 2 (each within the scatter of the next, the first and the last beyond it).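

With bromo at this position on the aromatic ring, this assay shows a 1.9-fold lower number from compound 2 to compound 3 (0.27 log units; within the scatter) and a 1.3-fold higher number from compound 1 to compound 3 (0.11 log units; within the scatter). Compound 3 therefore cannot be told apart from either neighbor, although compound 1 and compound 2 differ beyond the scatter, so the smaller bromo does not separate itself from the propyl or propoxy chains. Nothing measured here offers an explanation for these numbers. What the compounds shown leave open is how an amine, a carboxylic acid or a longer chain would read at this position.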